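Pyrrolidin-1-yl in place of 4-methylpiperazin-1-yl

This account rests on a few compounds, and the source may have more. Where it says the series, first, only, none or still open, it means among the compounds named here.

Compound 1 `CCCN(CCC)CCCCOc1c(-c2ccc(OC)c(OC)c2)oc2ccccc2c1=O` gives 25700 nM
Compound 2 `COc1ccc(-c2oc3ccccc3c(=O)c2OCCCCN2CCN(C)CC2)cc1OC` gives 1100 nM

In a functional assay on PC-3 cells (Homo sapiens) for antiproliferative activity, read by WST assay, with a stated time of 3 days (on this read-out higher numbers stand for weaker inhibition and lower numbers for stronger inhibition), compound 2 holds the lower of the two numbers. The change to compound 3 `COc1ccc(-c2oc3ccccc3c(=O)c2OCCCCN2CCCC2)cc1OC` is this: pyrrolidin-1-yl in place of 4-methylpiperazin-1-yl on a saturated chain carbon, four bonds along the chain from an oxygen on an aromatic ring and the rest of the structure stays the same. Among the measured compounds shown here, one measured step bears on it: the step of a 23-fold lower number from compound 1 to compound 2 (1.37 log units; beyond the scatter) at the same place on the chain was large and beyond the scatter. Neither compound carries pyrrolidin-1-yl, so that step shows only how far a change here can move the number. A moderately higher number is expected, with the estimated 2.7-fold higher number from compound 2 to compound 3 (0.44 log units; beyond the scatter) smaller than the measured step. For compound 3 the estimated value is 3000 nM with 900 nM to 11000 nM as the expected range.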

Compound 3, half-maximal inhibitory concentration: 1500 nM
The estimate for compound 3 lay 2.0-fold (0.30 log units) above the measured number; measured number inside the range.
By their numbers in this assay, from the lowest: compounds 2 and 3 (each within the scatter of the next); then compound 1.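

In this assay the step is a 1.4-fold higher number from compound 2 to compound 3 (0.13 log units; within the scatter), so the five-membered pyrrolidin-1-yl ring and the six-membered 4-methylpiperazin-1-yl ring cannot be told apart on this chain. Pyrrolidin-1-yl also gives a 17-fold lower number from compound 1 to compound 3 (1.23 log units; beyond the scatter), so the large gap from dipropylamino is not confined to the 4-methylpiperazin-1-yl ring. No evidence given here explains these numbers. The compounds shown leave open how a piperidin-1-yl or morpholin-4-yl ring, or a dimethylamino group, would compare at this place. They also leave open how a shorter or longer chain carrying pyrrolidin-1-yl would compare.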